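This account rests on a few compounds, and the source may have more. Where it says the series, first, only, none or still open, it means among the compounds named here.

Within the data shown here, in an ADME assay on cells (Hepatocyte, Homo sapiens) for metabolic stability (on this read-out higher numbers stand for a longer-lived compound and lower numbers for a shorter-lived compound), compound 2 `O=C(OC1CCC(CN2CCN(c3cc(=O)c4cc(C(F)(F)F)cc([N+](=O)[O-])c4s3)CC2)CC1)C1CCCCC1` gives 0.0967 h, the only exact number so far. Compound 1 `O=C(NC1CCC(CN2CCN(c3cc(=O)c4cc(C(F)(F)F)cc([N+](=O)[O-])c4s3)CC2)CC1)c1ccccc1` gives > 1.55 h, which is a limit of the assay. Compound 3 `COc1ccc(C(=O)OC2CCC(CN3CCN(c4cc(=O)c5cc(C(F)(F)F)cc([N+](=O)[O-])c5s4)CC3)CC2)cc1` differs from compound 2 by 4-methoxyphenyl in place of cyclohexyl on a carbonyl carbon, with 4-methoxyphenyl in place of cyclohexyl on a carbonyl carbon. Among the measured compounds shown here, the one measured step, an at least 16-fold lower number from compound 1 to compound 2 (1.20 log units; beyond the scatter), is large, but it put (cyclohexylcarbonyl)oxy in place of benzamido on a saturated ring carbon, a different change, so it sets no direction here. The expected change is small, within the scatter: a 1.2-fold higher number from compound 2 to compound 3 (0.09 log units; within the scatter). The estimate for compound 3 is 0.12 h, with an expected range of 0.05 h to 0.35 h.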

Compound 3, half-life: 0.165 h
Beside the measured number, compound 3's estimate is 1.4-fold (0.14 log units) below it, and the stated range covers the measured number.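

In this assay, 4-methoxyphenyl in place of cyclohexyl on a carbonyl carbon gives a 1.7-fold higher number from compound 2 to compound 3 (0.23 log units; within the scatter), so these two compounds cannot be told apart. An aromatic ring on this carbonyl carbon thus does not bring the ester back to the level of the benzamide, with an at least 9.3-fold lower number from compound 1 to compound 3 (0.97 log units; beyond the scatter). The value of compound 1 is a limit of the assay, not a number: the limit of > 1.55 h in this assay, at which 1 of the 3 values shown sits. Still open, going by these compounds, is whether an amine or a longer chain on this carbonyl carbon would shift the half-life, and whether an amide carrying cyclohexyl would match compound 1.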